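Swapping the Methoxyphenyl Arm for a Pyridin-3-yl Ring

The source may report more compounds than this note shows. Statements on the series, on what has been measured and on what is new or still open speak of the compounds shown alone.

In a functional assay on MCF7 cells (Homo sapiens) for antiproliferative activity, read by MTT assay, with a stated time of 48 h (on this read-out higher numbers stand for weaker inhibition and lower numbers for stronger inhibition), compound 2 `COc1ccc(C2OC(c3ccc4ccccc4c3)=NN2C(C)=O)cc1` gives 7.35 ug/mL, the highest number among the three compounds measured. Compound 1 `CC(=O)N1N=C(c2ccc3ccccc3c2)OC1c1ccccc1` gives 2.43 ug/mL, and compound 3 `CC(=O)N1N=C(c2ccc3ccccc3c2)OC1c1ccccn1` gives 6.02 ug/mL. Both a 3.0-fold higher number from compound 1 to compound 2 (0.48 log units; beyond the scatter) and a 2.5-fold higher number from compound 1 to compound 3 (0.39 log units; beyond the scatter) lie beyond the scatter, whereas a 1.2-fold lower number from compound 2 to compound 3 (0.09 log units; within the scatter) lies within it. Compound 4 `CC(=O)N1N=C(c2ccc3ccccc3c2)OC1c1cccnc1` differs from compound 2 in one place: pyridin-3-yl in place of 4-methoxyphenyl on a saturated ring carbon. The closest guide is the earlier change in which a pyridinyl ring also took the place of 4-methoxyphenyl on the same saturated ring carbon, and that change moved the number only within the scatter. The step of a 1.2-fold lower number from compound 2 to compound 4 (0.09 log units; within the scatter) is therefore expected to stay within the scatter. Compound 4 is estimated at 6 ug/mL, with a range from 3 ug/mL to 12 ug/mL.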

Compound 4, half-maximal inhibitory concentration: 2.61 ug/mL
Beside the measured number, compound 4's estimate is 2.3-fold (0.36 log units) above it; measured number outside the range, below it.
By their numbers in this assay, from the lowest: compounds 1 and 4 (each within the scatter of the next); then compounds 3 and 2 (each within the scatter of the next).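

In this assay this saturated ring carbon separates the two pyridinyl isomers, with a 2.3-fold lower number from compound 3 to compound 4 (0.36 log units; beyond the scatter) on moving from pyridin-2-yl to pyridin-3-yl, so they are not interchangeable here. Replacing 4-methoxyphenyl with pyridin-3-yl gives a 2.8-fold lower number from compound 2 to compound 4 (0.45 log units; beyond the scatter) where the pyridin-2-yl swap had stayed within the scatter, and replacing phenyl with pyridin-3-yl gives a 1.1-fold higher number from compound 1 to compound 4 (0.03 log units; within the scatter) and leaves compound 4 level with compound 1. No measurement shown accounts for the difference between the isomers. Still open, as far as these compounds go, is how pyridin-4-yl, or a phenyl ring carrying an amine or a carboxylic acid, would read at this carbon.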